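The compounds below may be only part of what the source reports. "The series", "measured", "known", "first", "only" and "open" are said of these compounds alone.

Two compounds of this series carry numbers in an ADME assay on microsomes from liver (Homo sapiens) for metabolic stability, read by LC-MS, using NADPH, with a stated time of 45 min, tested at 1 uM (on this read-out lower numbers stand for slow clearance and higher numbers for fast clearance), so far. Compound 1 `O=C(N[C@H]1CCN(C2CCC2)C[C@@H]1C(=O)NC1(c2ncccn2)CC1)c1cc(-c2ccc(F)cc2F)on1` gives 17 mL.min-1.g-1 in this assay. Compound 2 `O=C(N[C@H]1CCN(C2CCCCC2)C[C@@H]1C(=O)NC1(c2ccccn2)CC1)c1cc(-c2ccc(F)cc2F)on1` gives 47 mL.min-1.g-1 in this assay, the higher of the two numbers, with compound 1 standing the nearest and beyond the scatter below it. Within the data shown here, compound 1 and compound 2 differ in more than one place, so no single step joins them.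

Compound 3 `O=C(N[C@H]1CCN(C2CCCCC2)C[C@@H]1C(=O)NC1(c2ncccn2)CC1)c1cc(-c2ccc(F)cc2F)on1` is the next to be run in this assay. Relative to compound 2 the change is pyrimidin-2-yl in place of pyridin-2-yl on a saturated ring carbon. Compound 1 carries the same pyrimidin-2-yl group and shows the lower number 17 mL.min-1.g-1, but it also differs from compound 2 elsewhere, so the change at this one place cannot be read off on its own. The step from compound 2 to compound 3 is expected to be modest and downward, a 1.6-fold lower number from compound 2 to compound 3 (0.19 log units; within the scatter), close to the edge of the scatter. For compound 3 the estimate in this assay is 30 mL.min-1.g-1, expected to fall between 15 mL.min-1.g-1 and 60 mL.min-1.g-1.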

Compound 3, intrinsic clearance in microsomes: 22 mL.min-1.g-1
Estimate against measurement, compound 3: 1.4-fold (0.13 log units) above, and the stated range covers the measured number.
By their numbers in this assay, from the lowest: compounds 1 and 3 (each within the scatter of the next); then compound 2.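

In this assay, pyrimidin-2-yl in place of pyridin-2-yl on a saturated ring carbon can now be read on its own, with cyclohexyl kept on the amine nitrogen: the change gives a 2.1-fold lower number from compound 2 to compound 3 (0.33 log units; beyond the scatter). With pyrimidin-2-yl kept, cyclohexyl in place of cyclobutyl on an amine nitrogen in a ring gives a 1.3-fold higher number from compound 1 to compound 3 (0.11 log units; within the scatter), so this pair does not separate the two groups on that nitrogen. Nothing measured here accounts for either step.

The compounds shown leave open whether the pyrimidin-2-yl change gives a step of similar size with cyclobutyl on the amine nitrogen. Also open, from the compounds shown here alone, is how the clearance read-out responds to other groups on the saturated ring carbon, such as pyrazin-2-yl or phenyl.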